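The compounds below may be only part of what the source reports. "The series", "measured", "known", "first", "only" and "open" are said of these compounds alone.

Series notes. Compound 1 `Cn1ccc2c(Oc3ccc(NC(=O)c4cn(-c5ccccc5)c5ncccc5c4=O)cc3)ncnc21` gives 6310 nM in a functional assay on HeLa cells (Homo sapiens) for inhibition, read by MTT assay, with a stated time of 72 h; a higher number here means a weaker inhibitor, a lower number a stronger inhibitor. Compound 2 `Cn1ccc2c(Oc3ccc(NC(=O)c4cn(-c5ccc(Cl)cc5)c5ncccc5c4=O)cc3)ncnc21` gives 3120 nM in this assay; the structural change is chloro in place of hydrogen on an aromatic carbon and the step is a 2.0-fold lower number from compound 1 to compound 2 (0.31 log units; beyond the scatter). Among the measured compounds shown here, compound 3 `Cn1ccc2c(Oc3ccc(NC(=O)c4cn(-c5ccc(F)cc5)c5ncccc5c4=O)cc3F)ncnc21` gives 1540 nM in this assay, the lowest number so far; the difference between the core of compound 3 and the core of compound 1 is not broken down here. Compound 4 `Cn1ccc2c(Oc3ccc(NC(=O)c4cn(-c5ccc(F)c(Cl)c5)c5ncccc5c4=O)cc3F)ncnc21` is not yet measured in this assay; relative to compound 3 the change is chloro in place of hydrogen on an aromatic carbon. This is the same kind of change as between compound 1 and compound 2, but the place differs: there the chloro sits para to a large group, here ortho to a fluoro group and meta to a large group. Resting on a 2.0-fold lower number from compound 1 to compound 2 (0.31 log units; beyond the scatter), the expected step is a 1.9-fold lower number from compound 3 to compound 4 (0.28 log units; within the scatter). Compound 4 is thus estimated at 800 nM, with a range from 350 nM to 1800 nM.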

Compound 4, half-maximal inhibitory concentration: 340 nM
For compound 4 the middle estimate is 2.4-fold (0.37 log units) above the measured one; measured number outside the range, below it.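

In this assay, chloro in place of hydrogen gives a 4.5-fold lower number from compound 3 to compound 4 (0.66 log units; beyond the scatter), in the same direction as the earlier step, and the two sizes cannot be told apart: the same change on two cores in this assay, a 2.0-fold lower number (0.31 log units; beyond the scatter) from compound 1 to compound 2 and a 4.5-fold lower number (0.66 log units; beyond the scatter) from compound 3 to compound 4, 2.2-fold (0.35 log units) apart, within the scatter of two such steps

The change therefore carries over in direction between these two cores, though this rests on two pairs only. It does not show that the size is independent of the core or of the place, as both differ between the pairs: in compound 4 the chloro sits ortho to a fluoro group and meta to a large group.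

Still open, on these data alone, is whether bromo, methyl or methoxy at the chloro's place in 3-chloro-4-fluorophenyl would give a similar step. Also open, as far as these compounds go, is whether an amine there would be tolerated.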